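From methyl to cyano: what happens to solubility?

This account rests on a few compounds, and the source may have more. Where it says the series, first, only, none or still open, it means among the compounds named here.

Measured so far in a physicochemical assay for solubility, read by HPLC, using the shake flask method, in phosphate buffer, with a stated time of 20 h, at pH 6.5; on this read-out higher numbers stand for higher solubility and lower numbers for lower solubility:
- Compound 1 `CN1CCN(CC2CCN(c3nccc4[nH]c(C5CCCC5)nc34)CC2)CC1` gives < 5000 nM (a limit)
- Compound 2 `Cc1cc2[nH]c(-c3cc(F)cc(F)c3)nc2c(N2CCC(CN3CCN(C)CC3)CC2)n1` gives 200000 nM

The entry for compound 1 at < 5000 nM is a limit of the assay and not a number. Going by the values given here, compound 2 gives 200000 nM and so holds the only true number in this small set. It therefore has no measured neighbour to be ranked against with any precision.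

Compound 3 `CN1CCN(CC2CCN(c3nc(C#N)cc4[nH]c(-c5cc(F)cc(F)c5)nc34)CC2)CC1` differs from compound 2 in one place. The change counts as follows: cyano in place of methyl on an aromatic carbon.

Among the compounds with values here, no measured pair here shows what such a swap does, so any forecast is uncertain. Starting from compound 2 at 200000 nM there seems more room to fall than to rise, so a moderate drop beyond the usual scatter is expected. The expected change is a 2.9-fold lower number from compound 2 to compound 3 (0.46 log units; beyond the scatter) in this assay, with wide uncertainty. For compound 3 the estimated solubility is 70000 nM, with an expected range from 15000 nM to 200000 nM.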

Compound 3, solubility: < 5000 nM
Compound 3 ended at the assay's limit; the forecaster's own chance of this, stated with the estimate: 10%; at least 14-fold (1.14 log units) between middle value and limit.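

Going by these compounds alone, this pair gives the first direct reading of a change at this position, the aromatic carbon next to the ring nitrogen. In this assay, cyano in place of methyl gives an at least 40-fold lower number from compound 2 to compound 3 (1.60 log units; beyond the scatter), so a swap that adds only one heavy atom can move the read-out by far more than the usual scatter. Compound 3 gives < 5000 nM, which is a limit of the assay and not a number. The printed step is therefore only the smallest size the change can have, because the value stops at the assay's floor: the limit of < 5000 nM in this assay, at which 2 of the 3 values shown sit.

Going by these compounds, how far compound 3 really lies under that limit stays open, and so does whether the large fall belongs to the cyano group itself or would follow from replacing methyl at this place with other groups. A plain hydrogen, a chlorine atom, a methoxy group or a primary amine at the same carbon, on the same 3,5-difluorophenyl-bearing core, would help to separate these two readings in this assay.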